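Swapping a methoxy for hydrogen on compound 1

The source may hold more compounds than are shown below. What is called first, only, known or untested is meant among the compounds shown, and "the series" means these compounds.

Among the measured compounds shown here, in an ADME assay on MT4 cells (Homo sapiens) for cytotoxicity, read by MTT assay, with a stated time of 96 h (on this read-out lower numbers stand for higher toxicity in this test and higher numbers for lower toxicity in this test), compound 1 (`COc1ccc2[nH]cc(Cc3c(OC(C)=O)ccc4c(C)cc(=O)oc34)c2c1`) gives 72000 nM and compound 2 (`Cc1cc(=O)oc2c(CN3CCN(C/C=C/c4ccccc4)CC3)c(OC(=O)c3ccccc3)ccc12`) gives 45000 nM and these two numbers lie within the usual scatter of each other, so compound 1 stands level with its only measured neighbour. Compound 3 (`CC(=O)Oc1ccc2c(C)cc(=O)oc2c1Cc1c[nH]c2ccccc12`) is compound 1 with hydrogen in place of methoxy on an aromatic carbon. For the measured compounds named here, no measured pair shows what this swap does, so the estimated step of a 1.1-fold lower number from compound 1 to compound 3 (0.04 log units; within the scatter) is expected to stay within the scatter, with no direction favoured. Compound 3 is estimated at 65000 nM in this assay with an expected range of 28000 nM to 150000 nM for repeat measurements.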

Compound 3, half-maximal cytotoxic concentration: 100000 nM
Compound 3: middle estimate off by 1.5-fold (0.19 log units), on the low side, within the range that was stated.
By their numbers in this assay, from the lowest: compounds 2, 1 and 3 (each within the scatter of the next, the first and the last beyond it).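

In this assay, among the compounds shown here, this is the first direct look at the swap: hydrogen in place of methoxy gives a 1.4-fold higher number from compound 1 to compound 3 (0.14 log units; within the scatter) on the same core. At this aromatic carbon, then, methoxy and hydrogen cannot be told apart on this read-out, and the methoxy group is not required for the high number seen with compound 1. Nothing measured here points to a reason for this result.

Still open, on these data alone, is whether an amine, a carboxylic acid or a longer alkoxy chain at this carbon would move the number beyond the scatter.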